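The source may hold more compounds than are shown below. What is called first, only, known or untested is meant among the compounds shown, and "the series" means these compounds.

Measured so far:
- compound 1, `COc1cc(OC)c(/C=C(/SCc2ccc(Cl)c(Cl)c2)C(=O)c2ccc(Cl)cc2)c(OC)c1`: 10000 nM
- compound 2, `COc1cc(OC)c(/C=C(/SCc2ccc(Cl)cc2Cl)C(=O)c2ccc(Cl)cc2)c(OC)c1`: 1000 nM
- compound 3, `CN(C)c1ccc(/C=C(/SCc2ccc(Cl)c(Cl)c2)C(=O)c2ccc(Cl)cc2)cc1`: 50000 nM

All three numbers come from a functional assay on DU-145 cells (Homo sapiens) for inhibition, read by trypan blue exclusion, with a stated time of 96 h; on this read-out lower numbers stand for stronger inhibition of growth and higher numbers for weaker inhibition of growth. Compound 1 and compound 2 share a core and differ in one place: 2,4-dichlorophenyl in place of 3,4-dichlorophenyl on a saturated chain carbon bound to a sulfur. That change gave a 10-fold lower number from compound 1 to compound 2 (1.00 log units; beyond the scatter). Compound 3 carries a different core; in this assay compound 3 gives 50000 nM, the highest of the three numbers. How the core of compound 3 differs from the core of compound 1 is not broken down here.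

Compound 4, `CN(C)c1ccc(/C=C(/SCc2ccc(Cl)cc2Cl)C(=O)c2ccc(Cl)cc2)cc1`, is not yet measured. It stands to compound 3 as compound 2 stands to compound 1: 2,4-dichlorophenyl in place of 3,4-dichlorophenyl on a saturated chain carbon bound to a sulfur. The place is the same in both pairs, a saturated chain carbon bound to a sulfur, so this is the same kind of change seen once already. The expectation for compound 4 rests on that one earlier step, which gave a 10-fold lower number from compound 1 to compound 2 (1.00 log units; beyond the scatter), and on compound 3 giving 50000 nM. From the compounds shown here alone, whether the step carries across to the other core is untested, so the expected step for compound 4 is held somewhat smaller and with wide bounds: a 7.1-fold lower number from compound 3 to compound 4 (0.85 log units; beyond the scatter). For compound 4 in this assay the estimate is 7000 nM, between 1500 nM and 35000 nM.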

Compound 4, concentration for 50% growth inhibition: 50000 nM
Estimate against measurement, compound 4: 7.1-fold (0.85 log units) below; measured number above the stated range.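

In this assay, placing 2,4-dichlorophenyl in place of 3,4-dichlorophenyl on a saturated chain carbon bound to a sulfur gave no change at the digits printed from compound 3 to compound 4 (within the scatter). The step therefore does not carry unchanged from the core of compound 1 to the core of compound 3, and the two steps differ: the same change on two cores in this assay, a 10-fold lower number (1.00 log units; beyond the scatter) from compound 1 to compound 2 and no change at the digits printed (within the scatter) from compound 3 to compound 4, 10-fold (1.00 log units) apart, beyond the scatter of two such steps This shows that, for these two pairs, the size of the step depends on the core, but it does not show which structural difference between the cores is responsible or how the change would behave on any other core.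

The compounds shown leave open whether the lower number seen with compound 2 would recur on a third core, so one pair on each core gives no general rule for the series. Also open, from the compounds shown here alone, is how a carboxylic acid, an amine or a longer chain would behave on that saturated chain carbon bound to a sulfur, in place of either dichlorophenyl group.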